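Changing Two Stereocentres in Compound 2

A few compounds are considered here, and "the series" means these few. Any claim that something is new, unique, unknown or untested is made for them only; others in the source may bear on it.

In a physicochemical assay for metabolic stability, read by HPLC, with a stated time of 12 h, at pH 1.2 (a lower number here means that the compound disappears faster, a higher number that the compound lasts longer), compound 2, `O=C(O)[C@H](CO)NC(=O)[C@@H]1C[C@H](O)CN1`, gives > 12 h, which is a limit and not a number. Compound 1, `O=C(O)[C@H](CO)NC(=O)[C@H]1C[C@@H](O)CN1`, gives > 12 h, which is also a limit. The evidence so far is the limit of > 12 h in this assay, at which 2 of the 2 values shown sit, together with the fact that compounds 1 and 2 differ only in the configuration as drawn.

Compound 3, `O=C(N[C@H](CO)C(=O)O)[C@@H]1C[C@@H](O)CN1`, is related to compound 2 as follows: the two compounds have the same atoms and bonds and differ only in configuration as drawn: 2 of 3 stereo elements differ; a stereocentre at a saturated chain carbon is drawn S in compound 2 and R in compound 3; a stereocentre at a saturated ring carbon is drawn S in compound 2 and R in compound 3. Among the measured compounds shown here, the only measured step that bears on this is a step that the two limits leave unreadable from compound 1 to compound 2. On these data alone, its size cannot be read, and it changed stereocentres at saturated ring carbons only, so a change at a saturated chain carbon remains untested. No step beyond the usual scatter is expected in this assay, and the estimated change is a step that the limit leaves unreadable from compound 2 to compound 3. For compound 3, the expected half-life is about 20 h, with an estimated range from 12 h to 40 h.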

Compound 3, half-life: > 12 h
Compound 3 gave a limit, no number; the forecaster's own chance of this, stated with the estimate: 90%; the middle value lies beyond the limit too.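

In this assay compound 3 gives > 12 h, which is a limit and not a number. The steps among compound 1, compound 2 and compound 3 therefore cannot be read: the limit of > 12 h in this assay, at which 3 of the 3 values shown sit.

The compounds shown leave open how long each one actually lasts, and whether configuration changes its half-life at all.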